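This account rests on a few compounds, and the source may have more. Where it says the series, first, only, none or still open, it means among the compounds named here.

Among the compounds with values here, in an ADME assay on MT4 cells (Homo sapiens) for cytotoxicity, read by MTT assay (a lower number here means that less compound is tolerated, a higher number that more compound is tolerated), compound 2 `COc1ccc(C2CC2CSc2nc(C(C)c3c(F)cccc3F)c(C)c(=O)[nH]2)cc1` gives 37300 nM, the higher of the two numbers so far, while compound 1 `COc1ccc([C@@H]2C[C@H]2CSc2nc([C@H](C)c3c(F)cccc3F)c(C)c(=O)[nH]2)cc1` gives 14600 nM. Compound 3 `COc1ccc([C@@H]2C[C@H]2CSc2nc([C@@H](C)c3c(F)cccc3F)c(C)c(=O)[nH]2)cc1` keeps the same atoms and bonds as compound 2: the two compounds have the same atoms and bonds; at least one stereo element is drawn with a configuration in one of them and without one in the other: 3 of 3 stereo elements differ; a stereocentre at a saturated ring carbon is drawn without a configuration in compound 2 and R in compound 3; a stereocentre at a saturated ring carbon is drawn without a configuration in compound 2 and R in compound 3; a stereocentre at a saturated chain carbon is drawn without a configuration in compound 2 and S in compound 3. Within the data shown here, the one measured step that bears on this is a 2.6-fold higher number from compound 1 to compound 2 (0.41 log units; beyond the scatter), a modest one, tied to the fact that one of compounds 1 and 2 is drawn with a defined configuration and the other without, at the place where they differ. On that evidence, a shift of similar or smaller size is expected in this assay, with little beyond the scatter and a slight lean upward. The expected step is a 1.1-fold higher number from compound 2 to compound 3 (0.05 log units; within the scatter). For compound 3 the estimated value is 42000 nM, with an expected range of 16000 nM to 100000 nM.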

Compound 3, half-maximal cytotoxic concentration: 47200 nM
The estimate for compound 3 lay 1.1-fold (0.05 log units) below the measured number; measured number inside the range.
By their numbers in this assay, from the lowest: compound 1; then compounds 2 and 3 (each within the scatter of the next).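

In this assay, a change at one stereocentre alone now gives a step beyond the scatter: a 3.2-fold higher number from compound 1 to compound 3 (0.51 log units; beyond the scatter). Within the data shown here, the saturated chain carbon drawn S rather than R is the only difference behind that step: the fact that compounds 1 and 3 differ only in the configuration as drawn Compound 2, drawn without configurations, stays within the scatter of the fully drawn S compound, with a 1.3-fold higher number from compound 2 to compound 3 (0.10 log units; within the scatter).

As far as these compounds go, whether the two saturated ring stereocentres, drawn R in both defined compounds, matter in the same way stays open. Also open, from the compounds shown here alone, is whether the chain stereocentre keeps this effect when it carries a longer chain or an amine.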